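A few compounds are considered here, and "the series" means these few. Any claim that something is new, unique, unknown or untested is made for them only; others in the source may bear on it.

Measured in an ADME assay on NIH3T3 cells (Mus musculus) for cytotoxicity, read by MTT assay, with a stated time of 24 h; on this read-out lower numbers stand for stronger inhibition and higher numbers for weaker inhibition:
compound 1 `Cc1nnc(SCC(=O)N/N=c2/scc(-c3ccc(Cl)cc3)n2-c2ccccc2)s1`, 253 ug/mL
compound 2 `Cn1cnnc1SCC(=O)N/N=c1/scc(-c2ccc(Cl)cc2)n1-c1ccccc1`, 51.7 ug/mL

Compound 1 gives the highest of the two numbers in this assay. Among the measured compounds shown here, the only measured step is a 4.9-fold lower number from compound 1 to compound 2 (0.69 log units; beyond the scatter), a change at the ring attached to the sulfur, and it lies beyond the scatter. Compound 3 `Cc1nnc(SCC(=O)N/N=c2/scc(-c3ccc(Br)cc3)n2-c2ccccc2)s1` differs from compound 1 in a different place: bromo in place of chloro on an aromatic carbon, so that 4-chlorophenyl becomes 4-bromophenyl. For the measured compounds named here, no measured pair exchanges one halogen for another, so the known step shows only how far this series can move when the sulfur-bound ring is swapped and says nothing about this change. With nothing pointing either way, compound 3 is expected to give a number close to that of compound 1 in this assay, the expected step being a 1.1-fold lower number from compound 1 to compound 3 (0.04 log units; within the scatter), none beyond the scatter. Compound 3 is therefore estimated at 230 ug/mL, with a range from 110 ug/mL to 480 ug/mL.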

Compound 3, half-maximal inhibitory concentration: 55 ug/mL
Beside the measured number, compound 3's estimate is 4.2-fold (0.62 log units) above it, outside the stated range (below it).
By their numbers in this assay, from the lowest: compounds 2 and 3 (each within the scatter of the next); then compound 1.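

In this assay, the exchange of one halogen for another on the aromatic carbon gives a 4.6-fold lower number from compound 1 to compound 3 (0.66 log units; beyond the scatter) and so shows that this position, far from the sulfur-bound ring, also moves the number beyond the scatter. That single-atom change is about as large as a 4.9-fold lower number from compound 1 to compound 2 (0.69 log units; beyond the scatter) even though that earlier step replaced a whole ring, so two separate places on this scaffold can each shift the read-out by a similar amount. No measurement shown here explains the shift.

A 4-fluorophenyl or an unsubstituted phenyl at this position would help show whether the number keeps falling across the halogens or bromo is a special case. Going by these compounds, it also remains open whether the same exchange would have a similar effect with the 4-methyl-4H-1,2,4-triazol-3-yl group on the sulfur.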